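Alpha-methyl branching on the acylsulfonamide chain

The source may hold more compounds than are shown below. What is called first, only, known or untested is meant among the compounds shown, and "the series" means these compounds.

Measured compounds:
- compound 1 `O=C(CCc1ccccc1-c1ccc(OCCCOc2cccc(CSCCc3ccccc3)c2)cc1)NS(=O)(=O)c1cccs1`: 7100 nM
- compound 2 `Cc1cccc(OCCCOc2ccc(-c3ccccc3CCC(=O)NS(=O)(=O)c3cccs3)cc2)c1`: 1600 nM

Both compounds were run in an assay on isolated protein for binding affinity to prostaglandin E2 receptor EP4 subtype (Homo sapiens); a lower number here means a stronger inhibitor, a higher number a weaker inhibitor. Going by the values given here, compound 2 holds the lower of the two numbers; its only neighbour is compound 1, which differs by the phenethylsulfanyl group on the chain end, and the step of a 4.4-fold lower number from compound 1 to compound 2 (0.65 log units; beyond the scatter) is beyond the scatter.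

Compound 3 `Cc1cccc(OCCCOc2ccc(-c3ccccc3CC(C)C(=O)NS(=O)(=O)c3cccs3)cc2)c1` is not yet measured. It differs from compound 2 by methyl in place of hydrogen on a saturated chain carbon bound to a carbonyl carbon and a saturated chain carbon, that is, a methyl group introduced on the chain carbon next to the carbonyl, with the rest of the molecule unchanged.

Among the compounds with values here, no measured step touches this position: the one available step concerns the far end of the ether-linked chain and gives no guide to branching close to the carbonyl. With nothing in the series speaking for or against a change here, the expected step of a 1.3-fold higher number from compound 2 to compound 3 (0.10 log units; within the scatter) is essentially none beyond the scatter, with a wide range to reflect the lack of precedent. Compound 3 is therefore estimated at 2000 nM in this assay, within 600 nM to 7000 nM.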

Compound 3, inhibition constant: 1100 nM
For compound 3 the middle estimate is 1.8-fold (0.26 log units) above the measured one, within the range that was stated.
By their numbers in this assay, from the lowest: compounds 3 and 2 (each within the scatter of the next); then compound 1.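

In this assay, methyl in place of hydrogen on a saturated chain carbon bound to a carbonyl carbon and a saturated chain carbon gives a 1.5-fold lower number from compound 2 to compound 3 (0.16 log units; within the scatter), so compounds 2 and 3 cannot be told apart in this assay and the position accepts this one added methyl without a change beyond the scatter. Going by these compounds alone, this is the first reading at this position, and it sets the methyl apart from the only other change, the loss of phenethylsulfanyl, which gives a 4.4-fold lower number from compound 1 to compound 2 (0.65 log units; beyond the scatter) and so lies beyond the scatter. The data hold nothing that could account for either step.

From the compounds shown here alone, whether an ethyl group, a second methyl on the same carbon or a hydroxyl at this position also stays within the scatter of compound 3 remains open, so the limit of what the position accepts is unknown. Also open, going by these compounds, are whether the two mirror-image forms of compound 3 read alike and whether the methyl has the same small effect when phenethylsulfanyl is present, as in compound 1.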